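Swapping the triazole side chain for a pyrrolidine tail

A few compounds are considered here, and "the series" means these few. Any claim that something is new, unique, unknown or untested is made for them only; others in the source may bear on it.

Compound 1 `O=C1c2c[n+]([O-])c3ccccc3c2C(=O)c2c1c1ccccc1n2Cc1cn(C[C@@H](O)CO)nn1`: 140 nM
Compound 2 `CC1(C)O[C@@H](CO)[C@H](Cn2cc(Cn3c4c(c5ccccc53)C(=O)c3c[n+]([O-])c5ccccc5c3C4=O)nn2)O1`: 190 nM
Compound 3 `CC1(C)OCC(Cn2cc(Cn3c4c(c5ccccc53)C(=O)c3c[n+]([O-])c5ccccc5c3C4=O)nn2)O1`: 330 nM

Of the compounds shown here, three sharing one core have been measured in a functional assay on A-375 cells (Homo sapiens) for cytotoxicity, read by MTT assay, with a stated time of 72 h; on this read-out lower numbers stand for stronger inhibition and higher numbers for weaker inhibition. Compound 1 gives the lowest of the three numbers; compound 2 lies nearest to it, the step of a 1.4-fold higher number from compound 1 to compound 2 (0.13 log units; within the scatter) falling within the scatter, whereas compound 3 lies furthest, the step of a 2.4-fold higher number from compound 1 to compound 3 (0.37 log units; beyond the scatter) being modest but beyond the scatter. Between compounds 2 and 3 the step of a 1.7-fold higher number from compound 2 to compound 3 (0.24 log units; within the scatter) is within the scatter. All three measured steps only vary what hangs from the triazole; none of them removes the triazole itself.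

Compound 4 `O=C1c2c[n+]([O-])c3ccccc3c2C(=O)c2c1c1ccccc1n2CCN1CCCC1` does exactly that. Its difference from compound 1 is (pyrrolidin-1-yl)methyl in place of 1-(2,3-dihydroxypropyl)-1H-1,2,3-triazol-4-yl on a saturated chain carbon bound to an aromatic nitrogen. Among the compounds with values here, no measured step covers a change of this kind, so the three measured steps give only a weak guide: they show that altering this side chain moves the number by small amounts. On that basis compound 4 is expected to stay in the same region as compound 1, with a step of a 1.1-fold higher number from compound 1 to compound 4 (0.03 log units; within the scatter) and no change beyond the scatter expected in either direction, though the uncertainty is wide. The estimate for compound 4 in this assay is 150 nM, with a range from 40 nM to 600 nM.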

Compound 4, half-maximal inhibitory concentration: 430 nM
Compound 4: the middle estimate sits 2.9-fold (0.46 log units) below what was measured; measured number inside the range.
By their numbers in this assay, from the lowest: compounds 1, 2, 3 and 4 (each within the scatter of the next, the first and the last beyond it).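

In this assay, within the data shown here, the step of a 3.1-fold higher number from compound 1 to compound 4 (0.49 log units; beyond the scatter) is modest but beyond the scatter, and it is the first change at this place that removes the triazole altogether. It shows that 1-(2,3-dihydroxypropyl)-1H-1,2,3-triazol-4-yl can give way to (pyrrolidin-1-yl)methyl, on a saturated chain carbon bound to an aromatic nitrogen, with a higher number but with the value still in the same nanomolar range, so the triazole is not required for activity at that level in this series. Since the aromatic ring, the dihydroxypropyl part and the pyrrolidine all change in this one step, the step belongs to the exchange as a whole and not to any single one of these parts, and no measurement offered here accounts for its size.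

The compounds shown leave open whether the higher number follows from losing the triazole, from losing the diol or from bringing in the pyrrolidine. A morpholine or a dimethylamino group on the same ethyl chain, a longer chain carrying the pyrrolidine, or a triazole bearing a pyrrolidine would help to separate these parts.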